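The source may hold more compounds than are shown below. What is called first, only, known or untested is meant among the compounds shown, and "the series" means these compounds.

In a functional assay on HepG2 cells (Homo sapiens) for antiproliferative activity, read by MTT assay, with a stated time of 48 h (a lower number here means a stronger inhibitor, a higher number a weaker inhibitor), the measured compounds read as follows. Compound 1, `CCN(CC)CCNC(=O)c1ccc(C(CC)(CC)c2ccc(OCCC(O)(CC)CC)c(C)c2)n1CC`, gives 230 nM. Compound 2, `CCn1c(C(=O)NCC#N)ccc1C(CC)(CC)c1ccc(OCCC(O)(CC)CC)c(C)c1`, gives only the limit of the assay, > 50000 nM. Compound 3, `C=CCN(C)C(=O)c1ccc(C(CC)(CC)c2ccc(OCCC(O)(CC)CC)c(C)c2)n1CC`, likewise gives only the limit, > 50000 nM.

Compound 2 thus stands at the limit rather than at a number, the limit at which two of the three values sit (the limit of > 50000 nM in this assay, at which 2 of the 3 values shown sit). From compound 1 the step is an at least 210-fold higher number from compound 1 to compound 2 (2.33 log units; beyond the scatter), and the other exchange on the carbonyl carbon gives an at least 210-fold higher number from compound 1 to compound 3 (2.33 log units; beyond the scatter). Between compound 2 and compound 3 the two limits leave the step unreadable, a step that the two limits leave unreadable from compound 2 to compound 3.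

Compound 4, `CCn1c(C(=O)N(C)CC(=O)O)ccc1C(CC)(CC)c1ccc(OCCC(O)(CC)CC)c(C)c1`, is not yet measured. It differs from compound 2 by (carboxymethyl)(methyl)amino in place of (cyanomethyl)amino on a carbonyl carbon. Both measured steps that bear on this carbonyl carbon, those from compound 1, were large and went toward weaker inhibition, and neither compound changed there returned a number. Compound 4 is therefore expected to remain at the limit, so that a number no higher from compound 2 to compound 4 (the limit leaves the size open) is expected to be a step the assay cannot read. The estimate for compound 4 is 50000 nM, within a range from 10000 nM to 100000 nM.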

Compound 4, half-maximal inhibitory concentration: 5710 nM
The estimate for compound 4 lay 8.8-fold (0.94 log units) above the measured number, outside the stated range (below it).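

In this assay, the carbonyl carbon carried a group other than the (2-(diethylamino)ethyl)amino of compound 1 and still returned a number, which neither earlier exchange there had done. The (carboxymethyl)(methyl)amino group gives an at least 8.7-fold lower number from compound 2 to compound 4 (0.94 log units; beyond the scatter), and the carboxy in place of vinyl gives an at least 8.7-fold lower number from compound 3 to compound 4 (0.94 log units; beyond the scatter), yet this recovery is only partial, with a 25-fold higher number from compound 1 to compound 4 (1.39 log units; beyond the scatter). Compound 2 and compound 3 themselves remain at a limit, not at a number: the limit of > 50000 nM in this assay, at which 2 of the 4 values shown sit.

From the compounds shown here alone, the step from compound 2 to compound 4 brings in the carboxy group and the methyl on the amide-type nitrogen together, so the share of each stays open. Also open, going by these compounds, is how an ester of the carboxylic acid, a longer chain ending in a carboxylic acid, or a shorter chain ending in a diethylamine would read at this carbonyl carbon.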